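Naphthalen-1-yl replaces 4-cyanophenyl on the shared core

The compounds below may be only part of what the source reports. "The series", "measured", "known", "first", "only" and "open" are said of these compounds alone.

Measured so far in a functional assay on MDA-MB-231 cells (Homo sapiens) for antiproliferative activity, read by MTT assay, with a stated time of 48 h; on this read-out higher numbers stand for weaker inhibition and lower numbers for stronger inhibition:
- compound 1, `C=CS(=O)(=O)N1CCN(c2ncnc3sc(-c4ccccc4)cc23)CC1`: 54200 nM
- compound 2, `C=CS(=O)(=O)N1CCN(c2ncnc3sc(-c4ccc(C(F)(F)F)cc4)cc23)CC1`: 6410 nM
- compound 3, `C=CS(=O)(=O)N1CCN(c2ncnc3sc(-c4ccc(C#N)cc4)cc23)CC1`: 8050 nM

Compound 3 carries a 4-cyanophenyl group on the shared core. Its number is the second highest of the three; against compound 2 it lies within the scatter, while against compound 1 it is clearly lower, with a 6.7-fold lower number from compound 1 to compound 3 (0.83 log units; beyond the scatter). The step of an 8.5-fold lower number from compound 1 to compound 2 (0.93 log units; beyond the scatter) is of similar size, and a 1.3-fold higher number from compound 2 to compound 3 (0.10 log units; within the scatter) shows that trifluoromethyl and cyano cannot be told apart here.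

Compound 4, `C=CS(=O)(=O)N1CCN(c2ncnc3sc(-c4cccc5ccccc45)cc23)CC1`, differs from compound 3 as follows: naphthalen-1-yl in place of 4-cyanophenyl on an aromatic carbon. The measured steps all concern a single group placed on a phenyl ring; none concerns a second fused ring, so they bear on this change only loosely. Both substituted compounds stood below the plain phenyl of compound 1, and the naphthalen-1-yl group is also a larger group than hydrogen, so a number somewhere between compound 1 and compound 3 is expected in this assay, though a wide range must be allowed. Compound 4 is therefore estimated at 20000 nM, within 5000 nM to 80000 nM, which means an expected step of a 2.5-fold higher number from compound 3 to compound 4 (0.40 log units; beyond the scatter).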

Compound 4, half-maximal inhibitory concentration: 23700 nM
Compound 4: middle estimate off by 1.2-fold (0.07 log units), on the low side; low and high end bracket the measured number.
By their numbers in this assay, from the lowest: compounds 2 and 3 (each within the scatter of the next); then compound 4; then compound 1.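

In this assay, the position next to the ring sulfur accepts a second fused ring as well as a single group on a phenyl ring: naphthalen-1-yl still beats plain phenyl, with a 2.3-fold lower number from compound 1 to compound 4 (0.36 log units; beyond the scatter). It does not reach the two substituted phenyl groups, though, with a 2.9-fold higher number from compound 3 to compound 4 (0.47 log units; beyond the scatter) and a 3.7-fold higher number from compound 2 to compound 4 (0.57 log units; beyond the scatter), so among these four compounds a larger all-carbon group alone does not match 4-cyanophenyl or 4-(trifluoromethyl)phenyl. Nothing measured here explains why the groups fall in this order.

As far as these compounds go, it remains open whether a methoxy group, an amine or a carboxylic acid on the phenyl ring would give a lower number than compound 2 and compound 3. Also open, from the compounds shown here alone, is whether naphthalen-2-yl would behave like naphthalen-1-yl.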